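A Chloro Group Exchanged for a Hydroxymethylpyrrolidine

A few compounds are considered here, and "the series" means these few. Any claim that something is new, unique, unknown or untested is made for them only; others in the source may bear on it.

Of the compounds shown here, three of a shared core have been measured in an assay on CHO cells for displacement of a labelled ligand from adenosine receptor A3 (Homo sapiens), read by scintillation counting, with a stated time of 3 h; a higher number here means a weaker inhibitor, a lower number a stronger inhibitor. Compound 1 `O=[N+]([O-])c1ccc(Nc2nc3c(N4CCCC4)ncnc3s2)cc1` gives 3630 nM, compound 2 `Clc1ncnc2sc(Nc3cccc(Br)c3)nc12` gives 3900 nM, and compound 3 `Clc1ncnc2sc(Nc3ccccc3)nc12` gives 3670 nM. Compound 2 carries the highest of the three numbers, but its nearest neighbour, compound 3, and its furthest, compound 1, both sit within the scatter of it, so no order among the three can be claimed. Within the data shown here, the single step with one change is a 1.1-fold lower number from compound 2 to compound 3 (0.03 log units; within the scatter), which likewise does not rise above the scatter.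

Compound 4 `OC[C@@H]1CCCN1c1ncnc2sc(Nc3cccc(Br)c3)nc12` differs from compound 2 in one place: 2-(hydroxymethyl)pyrrolidin-1-yl in place of chloro on an aromatic carbon. Among the measured compounds shown here, none of the measured steps touches this position; compound 1 differs from compound 2 in more than one place, and its value and that of compound 2 are within the scatter of each other. There is thus no direct evidence for the size or direction of the change, and the step is expected to stay modest: the estimated step is a 1.3-fold lower number from compound 2 to compound 4 (0.11 log units; within the scatter). Compound 4 is expected to give about 3000 nM in this assay, with a range from 700 nM to 13000 nM.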

Compound 4, inhibition constant: 1070 nM
Compound 4: the middle estimate sits 2.8-fold (0.45 log units) above what was measured; the measured number falls inside the stated range.
By their numbers in this assay, from the lowest: compound 4; then compounds 1, 3 and 2 (each within the scatter of the next).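

In this assay, among these compounds, 2-(hydroxymethyl)pyrrolidin-1-yl in place of chloro on this aromatic carbon, next to the ring nitrogen, gives a 3.6-fold lower number from compound 2 to compound 4 (0.56 log units; beyond the scatter), so this position responds to a change in a way the earlier compounds could not show; the only earlier single-place step, a 1.1-fold lower number from compound 2 to compound 3 (0.03 log units; within the scatter), concerned the bromo and stayed within the scatter. The entering group differs from chloro in several ways at once, with its five-membered non-aromatic ring, its hydrogen-bond donor and acceptors and its defined stereocentre, and this one step cannot separate them. Nothing measured here accounts for the step.

The compounds shown leave open whether a plain pyrrolidine without the hydroxymethyl, the opposite stereoisomer of the hydroxymethylpyrrolidine, or another cyclic amine such as piperidine or morpholine would give a similar step from compound 2. They also leave open whether a longer chain such as hydroxyethyl, or a methyl ether in place of the hydroxyl, would keep the step, and whether it would persist with hydrogen in place of the bromo.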